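Sulfonamides on a Shared Core Against Mitochondrial Malate Dehydrogenase

A few compounds are considered here, and "the series" means these few. Any claim that something is new, unique, unknown or untested is made for them only; others in the source may bear on it.

Compound 1, `O=S(=O)(Nc1ccc2oc(-c3ccccc3)nc2c1)c1ccc(Cl)cc1`, gives in an assay on isolated protein for inhibition of malate dehydrogenase, mitochondrial (Sus scrofa), with stated times of 45 min and 30 min (a lower number here means a stronger inhibitor, a higher number a weaker inhibitor), the value > 63000 nM, a limit of the assay.
Compound 2, `O=S(=O)(Nc1ccc2oc(-c3ccccc3)nc2c1)c1ccc(Cl)c(C(F)(F)F)c1`, gives in this assay the value > 63000 nM, also a limit.
Compound 3, `O=[N+]([O-])c1cc(S(=O)(=O)Nc2ccc(-c3nc4ccccc4o3)cc2)ccc1Cl`, gives in this assay the value > 63000 nM, again a limit.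

Compound 1 therefore stands only at a limit, as do the other two measured compounds, all sitting at the limit of > 63000 nM in this assay, at which 3 of the 3 values shown sit. For the measured compounds named here, the one measured step, a step that the two limits leave unreadable from compound 1 to compound 2, cannot be read because both ends are limits. Compound 4, `O=S(=O)(Nc1ccc2oc(-c3ccccc3)nc2c1)c1ccccc1O`, differs from compound 1 by 2-hydroxyphenyl in place of 4-chlorophenyl on a sulfonyl sulfur. No measured step bears on this change, so nothing shown points to a gain or a loss beyond the scatter. Compound 4 is therefore expected to give 63000 nM, within 12000 nM to 300000 nM, a step of a number no higher from compound 1 to compound 4 (the limit leaves the size open) that is most likely to appear again as a limit.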

Compound 4, half-maximal inhibitory concentration: > 63000 nM
Compound 4: no number, only a limit (the forecaster's own chance of this, stated with the estimate: 80%); the middle value lies on the limit itself.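

The step from compound 1 to compound 4 cannot be read, since both values are limits of the assay and neither is a number: the limit of > 63000 nM in this assay, at which 4 of the 4 values shown sit.

The compounds shown leave open which change to the shared core, if any, would give a measurable value in this assay.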